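Swapping thiophene for furan on the shared core

The compounds below may be only part of what the source reports. "The series", "measured", "known", "first", "only" and "open" are said of these compounds alone.

- compound 1 `Fc1ccc(N2CCN(CCCc3c[nH]c4ccc(F)cc34)CC2)c(-c2cn[nH]c2)c1`: 0.12 h
- compound 2 `Fc1ccc(N2CCN(CCCc3c[nH]c4ccc(F)cc34)CC2)c(-c2ccsc2)c1`: 0.408 h

Both half-lives come from an ADME assay on microsomes from liver (Rattus norvegicus) for metabolic stability, read by LC-MS, using NADPH, with a stated time of 90 min, tested at 1 uM; a higher number here means that the compound lasts longer, a lower number that the compound disappears faster. Compound 2 has the higher of the two numbers, and the gap to compound 1 lies beyond the usual scatter.

The next structure is compound 3 `Fc1ccc(N2CCN(CCCc3c[nH]c4ccc(F)cc34)CC2)c(-c2ccoc2)c1`, with furan-3-yl in place of thiophen-3-yl on an aromatic carbon. Among the measured compounds shown here, the shared core stays the same, and only one ring atom differs in the five-membered aromatic ring.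

Just one measured step bears on this change: a 3.4-fold higher number from compound 1 to compound 2 (0.53 log units; beyond the scatter). It was modest, and it replaced a different ring, 1H-pyrazol-4-yl, at the same place. For the measured compounds named here, no furan-3-yl compound has been measured, so this step gives only a rough idea of how far a ring swap here can move the number. Going by the values given here, with compound 2 at 0.408 h, the higher of only two values, a small fall in this assay seems more likely than a further rise, and it may well stay within the scatter.

The expected change is a 1.4-fold lower number from compound 2 to compound 3 (0.15 log units; within the scatter). Compound 3 is estimated at 0.29 h, with an expected range from 0.14 h to 0.58 h.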

Compound 3, half-life: 0.172 h
Beside the measured number, compound 3's estimate is 1.7-fold (0.23 log units) above it; the range from low to high includes it.
By their numbers in this assay, from the lowest: compounds 1 and 3 (each within the scatter of the next); then compound 2.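

In this assay, exchanging the ring sulfur of thiophen-3-yl for the ring oxygen of furan-3-yl gives a 2.4-fold lower number from compound 2 to compound 3 (0.38 log units; beyond the scatter), so a change of one ring atom at this position, on an aromatic carbon ortho to a large group, is enough to move the half-life beyond the usual scatter, even though the two groups have the same counts of heavy atoms, hydrogen-bond donors and acceptors. The other new comparison gives a 1.4-fold higher number from compound 1 to compound 3 (0.16 log units; within the scatter), which lies within the scatter, so furan-3-yl and 1H-pyrazol-4-yl cannot be told apart in this assay, and among these three compounds only compound 2, with thiophen-3-yl, stands clear of the others. No measurement available here accounts for the gap between the sulfur and oxygen rings.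

The compounds shown leave open whether a six-membered ring such as pyridin-3-yl, or a thiazole, at this position would match or pass the half-life of compound 2. They also leave open whether thiophen-3-yl would keep its lead over furan-3-yl on a different core.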